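A few compounds are considered here, and "the series" means these few. Any claim that something is new, unique, unknown or untested is made for them only; others in the source may bear on it.

Compound 3, `C=CCSC(=O)/C=C(C)/C=C/CC(C)CCCC(C)(C)OC`, stands second highest of the three numbers measured in a physicochemical assay for lipophilicity; a lower number here means a more polar compound, a higher number a more lipophilic compound: compound 3 gives 6.77, compound 2, `COC(C)(C)CCCC(C)C/C=C/C(C)=C/C(=O)SC(C)C`, gives 7.19, and compound 1, `C=CCOC(=O)/C=C(C)/C=C/CC(C)CCCC(C)(C)OC`, gives 5.53. The steps among them are mostly about the group attached to the carbonyl carbon. There is a number a number 1.66 log units higher from compound 1 to compound 2 (beyond the scatter), and a number a number 1.24 log units higher from compound 1 to compound 3 (beyond the scatter), both large and both beyond the scatter. The step among the two sulfur-bearing compounds is smaller, a number a number 0.42 log units lower from compound 2 to compound 3 (beyond the scatter).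

Compound 4, `COC(C)(C)CCCC(C)C/C=C/C(C)=C/C(=O)CC(C)C`, is a new, unmeasured compound. Its difference from compound 3 is isobutyl in place of allylsulfanyl on a carbonyl carbon. Among the measured compounds shown here, no measured step covers exactly this change: the steps from compound 1 show what happens when sulfur replaces oxygen, and the step from compound 2 to compound 3 shows a swap of one carbon chain for another on sulfur, but none removes the sulfur in favour of carbon. The expectation is therefore cautious and rests on the trend that the largest movements in this assay came with the sulfur. For compound 4 the expected value is 6.3, within a range of 5.8 to 6.8, which would mean an estimated step of a number 0.47 log units lower from compound 3 to compound 4 (beyond the scatter), a modest lowering.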

Compound 4, partition coefficient: 6.02
Estimate against measurement, compound 4: 0.28 log units above; low and high end bracket the measured number.
By their numbers in this assay, from the lowest: compound 1; then compound 4; then compound 3; then compound 2.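

The change from a sulfur-linked group to isobutyl on this carbonyl carbon lowers the number in this assay, both with allylsulfanyl leaving (a number 0.75 log units lower from compound 3 to compound 4 (beyond the scatter)) and with isopropylsulfanyl leaving (a number 1.17 log units lower from compound 2 to compound 4 (beyond the scatter)). Isobutyl in place of the oxygen-linked allyloxy moves the number the other way (a number 0.49 log units higher from compound 1 to compound 4 (beyond the scatter)), so among these four compounds the carbon-linked group sits between the oxygen-linked group and the two sulfur-linked groups, with no compound going against that order. Among the compounds shown here, this is the first view of the position with neither oxygen nor sulfur joined to the carbonyl carbon, although no measurement here explains why the groups fall in this order.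

Among the compounds shown, isobutyl is the only group joined through carbon, so a straight butyl chain or a shorter ethyl group might land elsewhere. Also open, from the compounds shown here alone, is where a group joined through nitrogen, such as dimethylamino, would fall in this order, and whether the same order would hold on a different core.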